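A few compounds are considered here, and "the series" means these few. Any claim that something is new, unique, unknown or untested is made for them only; others in the source may bear on it.

Compound 1 `C=CCOC(=O)C1=C(C)NC(C)=C(C(=O)OC)C1c1cccc([N+](=O)[O-])c1` and compound 2 `CCOC(=O)C1=C(C)NC(C)=C(C(=O)OCCOC)C1c1cccc([N+](=O)[O-])c1` share one core and differ only in their ester groups. In a functional assay on HEK293 cells for antagonist activity at Voltage-dependent L-type calcium channel subunit alpha-1C (Oryctolagus cuniculus), read by FLIPR (a higher number here means a weaker inhibitor, a lower number a stronger inhibitor), compound 1 gives 15 nM, and compound 2 gives 16 nM; compound 1 has the lower of the two numbers, yet its gap to compound 2 sits within the scatter, so the two cannot be ranked. Compound 3 `COC(=O)C1=C(C)NC(C)=C(C(=O)OCc2ccco2)C1c1cccc([N+](=O)[O-])c1` differs from compound 1 by furan-2-yl in place of vinyl on a saturated chain carbon bound to an oxygen next to a carbonyl group. For the measured compounds named here, no measured pair shows this change, so the expected step is small, none beyond the scatter, as no change at the digits printed from compound 1 to compound 3 (within the scatter). Compound 3 is expected to give about 15 nM, between 5 nM and 50 nM.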

Compound 3, half-maximal inhibitory concentration: 20 nM
Beside the measured number, compound 3's estimate is 1.3-fold (0.12 log units) below it, and the stated range covers the measured number.
By their numbers in this assay, from the lowest: compounds 1, 2 and 3 (each within the scatter of the next).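

Furan-2-yl in place of vinyl on a saturated chain carbon bound to an oxygen next to a carbonyl group gives a 1.3-fold higher number from compound 1 to compound 3 (0.12 log units; within the scatter) in this assay and so stays within the scatter. This position therefore accepts a five-membered aromatic ring of 5 heavy atoms in place of a group of 2 with no loss that these numbers can show. Nothing measured here bears on the reason for this result.

Still open, on these data alone, is whether this position would accept an amine or a carboxylic acid at the end of the ester chain. A much longer chain is equally untested by the compounds shown.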